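A pyridin-2-yl swap on compound 1

A few compounds are considered here, and "the series" means these few. Any claim that something is new, unique, unknown or untested is made for them only; others in the source may bear on it.

Measured so far in a physicochemical assay for lipophilicity, at pH 7.4; a higher number here means a more lipophilic compound, a lower number a more polar compound
compound 1 `CNC(=O)c1cc(C(=O)N[C@H]2[C@@H]3COC[C@@H]32)cc2c1OC[C@H]2c1cccnc1` 1.4
compound 2 `CNC(=O)c1cc(C(=O)N[C@H]2C[C@@H]2C)cc2c1OC[C@@]2(C)c1ccccc1` 4.7

Compound 1 is the lower of the two, and its gap to compound 2 lies beyond the usual scatter. The unmeasured compound 3 `CNC(=O)c1cc(C(=O)N[C@H]2[C@@H]3COC[C@@H]32)cc2c1OC[C@H]2c1ccccn1` has the same atoms as compound 1, joined differently. The change pyridin-2-yl in place of pyridin-3-yl on a saturated ring carbon puts pyridin-2-yl in place of pyridin-3-yl on a saturated ring carbon. Among the compounds with values here, no measured pair shows a step of this kind, so the expectation rests on the structural change alone: a small upward move in this assay close to the scatter. An estimated a number 0.30 log units higher from compound 1 to compound 3 (within the scatter) is what this suggests. Compound 3 is estimated at 1.7 with 1.3 to 2.1 as the expected range.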

Compound 3, distribution coefficient: 1.6
Estimate against measurement, compound 3: 0.10 log units above; the measured number falls inside the stated range.
By their numbers in this assay, from the lowest: compounds 1 and 3 (each within the scatter of the next); then compound 2.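

Putting pyridin-2-yl in place of pyridin-3-yl on a saturated ring carbon gives, in this assay, a number 0.20 log units higher from compound 1 to compound 3 (within the scatter) and so does not separate the two groups in this assay. Within the data shown here, this is the first comparison here of compounds that differ in one place. No measured evidence bears on this result.

Still open, going by these compounds, is how this assay would respond to a group of another kind at this carbon, such as an amine or a carboxylic acid. Compound 2 differs from compound 1 in more than one place and cannot answer that.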